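A few compounds are considered here, and "the series" means these few. Any claim that something is new, unique, unknown or untested is made for them only; others in the source may bear on it.

Of the compounds shown here, three have so far been tested in an ADME assay on HUVEC cells (Homo sapiens) for cytotoxicity, read by MTT assay, with a stated time of 48 h; on this read-out lower numbers stand for stronger inhibition and higher numbers for weaker inhibition. Compound 1 `O=C(NCCOC(=S)Nc1ccc([N+](=O)[O-])cc1Cl)c1cccnc1` gives 701000 nM. Compound 2 `Cc1ccc(NC(=S)OCCNC(=O)c2cccnc2)cc1` gives 567000 nM. Compound 3 `CC(C)(Oc1ccc(Cl)cc1)C(=O)NCCOC(=S)Nc1ccc([N+](=O)[O-])cc1Cl` gives 729000 nM. Compound 2 has the lowest of the three numbers, yet its gaps to compound 1 and to compound 3 both lie within the usual scatter of repeated measurements, so the three compounds cannot be told apart on these numbers; all three sit at very high concentrations.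

The next compound, compound 4 `O=C(NCCOC(=S)Nc1ccccc1)c1cccnc1`, differs from compound 2 in one place: hydrogen in place of methyl on an aromatic carbon. Among the compounds with values here, no pair of measured compounds differs by this same change, so no measured step shows what it does here. With the three measured numbers so close to each other, and the change so small, the expectation is no step beyond the scatter, and a 1.1-fold higher number from compound 2 to compound 4 (0.02 log units; within the scatter) is the step expected. Compound 4 is therefore expected to give about 600000 nM in this assay, most likely between 300000 nM and 1200000 nM.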

Compound 4, half-maximal inhibitory concentration: 724000 nM
Estimate against measurement, compound 4: 1.2-fold (0.08 log units) below; measured number inside the range.
By their numbers in this assay, from the lowest: compounds 2, 1, 4 and 3 (each within the scatter of the next).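

Within the data shown here, replacing 4-methylphenyl with phenyl gives a 1.3-fold higher number from compound 2 to compound 4 (0.11 log units; within the scatter) in this assay, the first measured look at this change at this position. On an aromatic carbon para to a large group, the methyl therefore makes no difference that this read-out can separate from repeat measurement, at least in this one pair of compounds. Nothing measured here speaks to why the methyl leaves the number within the scatter.

Going by these compounds, it remains open whether a different group at this same carbon, such as an amine, a carboxylic acid or a longer chain like propyl, would produce a step beyond the scatter. Also open, on these data alone, is whether removing a methyl from an aromatic carbon gives a similar result on any other core.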